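Extending the side chain of compound 2

A few compounds are considered here, and "the series" means these few. Any claim that something is new, unique, unknown or untested is made for them only; others in the source may bear on it.

Measured so far in a physicochemical assay for lipophilicity; a lower number here means a more polar compound, a higher number a more lipophilic compound:
- compound 1 `CCCCC(=O)Nc1nc2ccccc2n1CCC`: 3.9
- compound 2 `CCCn1c(NC(=O)CCc2ccccc2)nc2ccccc21`: 4.6

Compound 2 holds the higher of the two numbers, at 4.6. Compound 3 `CCCn1c(NC(=O)CCCc2ccccc2)nc2ccccc21` has not been measured. It differs from compound 2 in one place: benzyl in place of phenyl on a saturated chain carbon, two bonds along the chain from a carbonyl carbon.

Among the compounds with values here, one measured step bears on this: a number 0.70 log units higher from compound 1 to compound 2 (beyond the scatter). That step brought in the aromatic ring, whereas compound 2 and compound 3 both carry one, so a smaller upward move in this assay is expected. The expected step is a number 0.40 log units higher from compound 2 to compound 3 (beyond the scatter). For compound 3 the estimated value is 5, with an expected range of 4.6 to 5.4.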

Compound 3, partition coefficient: 5
Estimate against measurement, compound 3: no gap at the digits printed; the measured number falls inside the stated range.
By their numbers in this assay, from the lowest: compound 1; then compound 2; then compound 3.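

In this assay, the added chain carbon still moves the number with an aromatic ring on both sides of the change: a number 0.40 log units higher from compound 2 to compound 3 (beyond the scatter). Across the whole series, phenyl in place of methyl on the saturated chain gives the widest span: a number 1.10 log units higher from compound 1 to compound 3 (beyond the scatter). Nothing measured here explains the size of either step.

From the compounds shown here alone, it remains open whether a longer chain ending in phenyl would keep raising the number. An amine or a carboxylic acid on that chain could also pull it back down.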